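This account rests on a few compounds, and the source may have more. Where it says the series, first, only, none or still open, it means among the compounds named here.

Among the measured compounds shown here, in a functional assay on MGC-803 cells (Homo sapiens) for inhibition, read by sulforhodamine B assay (a lower number here means a stronger inhibitor, a higher number a weaker inhibitor), compound 2 `Cc1ccc(NC2=CC(=O)c3c(nc4n3[C@H]3OC[C@@H](O)[C@H]3OC4)C2=O)cc1` gives 1550 nM, the only exact number so far. Compound 1 `O=C1C(NC2CCCC2)=CC(=O)c2c1nc1n2[C@H]2OC[C@@H](O)[C@H]2OC1` gives > 16000 nM, which is a limit of the assay and not a number. For the measured compounds named here, one measured step bears on what follows: an at least 10-fold lower number from compound 1 to compound 2 (1.01 log units; beyond the scatter), with 4-methylphenyl in place of cyclopentyl on an amine nitrogen. That step is large and beyond the scatter. Compound 3 `O=C1C(N2CCC2)=CC(=O)c2c1nc1n2[C@H]2OC[C@@H](O)[C@H]2OC1` carries azetidin-1-yl in place of (4-methylphenyl)amino on a double-bonded ring carbon, (azetidin-1-yl in place of (4-methylphenyl)amino on a double-bonded ring carbon). Like compound 1, it has no aromatic ring in this group, so a sizeable move towards a higher number, meaning weaker inhibition, is expected, although this single step is thin support. The expected change is a 4.5-fold higher number from compound 2 to compound 3 (0.65 log units; beyond the scatter). For compound 3 the estimated value is 7000 nM, with an expected range from 2000 nM to 25000 nM.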

Compound 3, half-maximal inhibitory concentration: > 16000 nM
Compound 3: no number, only a limit; the forecaster's own chance of this, stated with the estimate: 35%; middle value at least 2.2-fold (0.35 log units) away from the limit.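

In this assay, azetidin-1-yl on the double-bonded ring carbon gives an at least 10-fold higher number from compound 2 to compound 3 (1.01 log units; beyond the scatter), so a second group without an aromatic ring also stands far from compound 2. Among the three groups shown at this place, only (4-methylphenyl)amino gives an exact number, and this now holds for both cyclopentylamino and a ring whose nitrogen carries no hydrogen-bond donor. The step between compound 1 and compound 3 cannot be read, since each end is a limit of the assay and not a number: the limit of > 16000 nM in this assay, at which 2 of the 3 values shown sit.

The compounds shown do not separate the part played by the aromatic ring from that of the amine hydrogen, as both are lost together in compound 3. Nor do they show what the methyl group contributes, which a plain phenylamino or a 4-methoxyphenylamino group at this place would address.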